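From Chloro to Methoxy on the Shared Core

A few compounds are considered here, and "the series" means these few. Any claim that something is new, unique, unknown or untested is made for them only; others in the source may bear on it.

Compound 1 `Nc1ncnc2c1nc(Cl)n2Cc1ccccc1` gives > 10 uM in a functional assay (spleen, spleen) for activation, with Mus musculus as the target (a higher number here means that more compound is needed for the effect, a lower number that less compound is needed), which is a limit of the assay and not a number.
Compound 2 `Nc1ncnc2c1nc(O)n2Cc1ccc(F)cc1` gives 10 uM in this assay.
Compound 3 `COc1cccc(Cn2c(O)nc3c(N)ncnc32)c1` gives 10 uM in this assay.

Compound 1 therefore stands only at a limit of this assay, as recorded in the limit of > 10 uM in this assay, at which 1 of the 3 values shown sits. Compounds 2 and 3 sit at the same number as each other. Compound 4 `COc1nc2c(N)ncnc2n1Cc1ccccc1` has not yet been measured in this assay. It differs from compound 1 in one place: methoxy in place of chloro on an aromatic carbon. Within the data shown here, no step between two measured compounds bears on this change, so the direction can only be guessed. A step of a number no higher from compound 1 to compound 4 (the limit leaves the size open) toward a measurable number is expected, of modest size. Compound 4 is estimated at 10 uM, with a range from 3 uM to 30 uM.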

Compound 4, minimum effective concentration: > 10 uM
Compound 4 gave a limit, no number (the forecaster's own chance of this, stated with the estimate: 40%); the middle value lies on the limit itself.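

Compound 1 and compound 4 both stand at a limit of this assay, so no step can be read between them: the limit of > 10 uM in this assay, at which 2 of the 4 values shown sit.

The compounds shown leave open whether methoxy in place of chloro on an aromatic carbon changes the concentration needed, and in which direction.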